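This account rests on a few compounds, and the source may have more. Where it says the series, first, only, none or still open, it means among the compounds named here.

The measured compounds:
Compound 1, `O=C(O)CCC(=O)OCCCCCCSc1ccc([N+](=O)[O-])c2nonc12`: 160 nM
Compound 2, `Cc1ccccc1NC(=O)CCC(=O)OCCCCCCSc1ccc([N+](=O)[O-])c2nonc12`: 440 nM
Compound 3, `O=C(CCC(=O)OCCCCCCSc1ccc([N+](=O)[O-])c2nonc12)Nc1ccc(F)cc1`: 320 nM

All three were tested in an assay on isolated protein for inhibition of glutathione S-transferase Mu 2 (Homo sapiens), with a stated time of 10 min; a lower number here means a stronger inhibitor, a higher number a weaker inhibitor. Compound 3 stands second highest of the three numbers: its nearest neighbour is compound 2, and the step of a 1.4-fold lower number from compound 2 to compound 3 (0.14 log units; within the scatter) lies within the scatter, as does the step of a 2.0-fold higher number from compound 1 to compound 3 (0.30 log units; within the scatter), so compound 3 is not clearly separated from either. Among the compounds with values here, only the step of a 2.8-fold higher number from compound 1 to compound 2 (0.44 log units; beyond the scatter) is modest but beyond the scatter.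

Compound 4, `O=C(CCC(=O)OCCCCCCSc1ccc([N+](=O)[O-])c2nonc12)NCCN1CCCC1`, has not yet been measured. It differs from compound 3 in one place: 2-(pyrrolidin-1-yl)ethyl in place of 4-fluorophenyl on an amide-type nitrogen. Within the data shown here, the only measured step on this amide-type nitrogen is a 1.4-fold lower number from compound 2 to compound 3 (0.14 log units; within the scatter), in which 4-fluorophenyl replaced 2-methylphenyl without moving the number beyond the scatter. Among the measured compounds shown here, no measured step exchanges 4-fluorophenyl for 2-(pyrrolidin-1-yl)ethyl, so the expectation rests on that small movement alone and is uncertain. The expected step is a 1.3-fold higher number from compound 3 to compound 4 (0.10 log units; within the scatter), within the scatter. Compound 4 is therefore estimated at 400 nM, with a range from 150 nM to 1100 nM.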

Compound 4, half-maximal inhibitory concentration: 200 nM
Estimate against measurement, compound 4: 2.0-fold (0.30 log units) above; the measured number falls inside the stated range.
By their numbers in this assay, from the lowest: compounds 1, 4, 3 and 2 (each within the scatter of the next, the first and the last beyond it).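

In this assay, within the data shown here, the amide-type nitrogen had so far carried only 4-fluorophenyl and 2-methylphenyl, and compound 4 shows that a group with a non-aromatic ring and a nitrogen atom, 2-(pyrrolidin-1-yl)ethyl, can sit there without losing inhibition against any of the earlier compounds. Among these compounds, it cannot be told apart from the aromatic amide compound 3 (a 1.6-fold lower number from compound 3 to compound 4 (0.20 log units; within the scatter)) or from the acid compound 1 (a 1.3-fold higher number from compound 1 to compound 4 (0.10 log units; within the scatter)), and its one step beyond the scatter, a modest one, favours it over the other aromatic amide (a 2.2-fold lower number from compound 2 to compound 4 (0.34 log units; beyond the scatter)). No measurement here explains this tolerance.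

From the compounds shown here alone, it remains open how 3-(pyrrolidin-1-yl)propyl, with its longer chain, or 2-(morpholin-4-yl)ethyl would behave on the same nitrogen. A plain 2-aminoethyl group would show whether the pyrrolidine ring is needed at all.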